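This account rests on a few compounds, and the source may have more. Where it says the series, first, only, none or still open, it means among the compounds named here.

Within the data shown here, in an ADME assay on Vero 76 cells (Chlorocebus sabaeus) for cytotoxicity, read by crystal violet staining, with a stated time of 96 h (a lower number here means that less compound is tolerated, a higher number that more compound is tolerated), compound 1 `O=[N+]([O-])c1ccc(NC(=S)Nc2cccc(C(F)(F)F)c2)cc1` gives 10000 nM, the only exact number so far. Compound 2 `CCNC(=S)Nc1cccc(C(F)(F)F)c1` reads > 100000 nM, which is a limit of the assay. Compound 3 `CCOC(=O)c1ccc(NC(=S)Nc2cccc(C(F)(F)F)c2)cc1` is still unmeasured and carries ethoxycarbonyl in place of nitro on an aromatic carbon, para to a large group: ethoxycarbonyl in place of nitro on an aromatic carbon. Among the measured compounds shown here, no measured step covers this change, so the expectation stays loose: a modest rise in tolerated concentration, with the estimated step of a 2.0-fold higher number from compound 1 to compound 3 (0.30 log units; within the scatter). The estimate in this assay for compound 3 is 20000 nM, with an expected range of 6000 nM to 70000 nM.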

Compound 3, half-maximal cytotoxic concentration: 71000 nM
Compound 3: the middle estimate sits 3.6-fold (0.55 log units) below what was measured, outside the stated range (above it).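

Among these compounds, at this position, para to a large group, the choice of group matters more than the earlier compounds could show: in this assay, ethoxycarbonyl in place of nitro gives a 7.1-fold higher number from compound 1 to compound 3 (0.85 log units; beyond the scatter). Both groups count the same hydrogen-bond donors and acceptors and differ in heavy atoms, so those donor and acceptor counts do not separate them.

Among the compounds shown here, compound 2 is a limit and not a number, so it gives no step: the limit of > 100000 nM in this assay, at which 1 of the 3 values shown sits. Whether a carboxylic acid, an amine or methoxycarbonyl at this position follows ethoxycarbonyl or nitro remains open.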